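From pyrrolidin-1-yl to piperidin-1-yl on a thiocarbonyl carbon

The source may report more compounds than this note shows. Statements on the series, on what has been measured and on what is new or still open speak of the compounds shown alone.

Compound 1 `CCCCCCOP(=O)(O)OCCSC(=S)N1CCCCCC1`: 17200 nM
Compound 2 `CCCCCCOP(=O)(O)OCCSC(=S)N1CCCC1`: 54000 nM

Both compounds were tested in a functional assay on MDA-MB-231 cells (Homo sapiens) for inhibition, read by MTT assay, with stated times of 18 h and 4 h; on this read-out higher numbers stand for weaker inhibition and lower numbers for stronger inhibition. Of the two, compound 2 stands highest at 54000 nM, so it is the weaker inhibitor. The next compound is compound 3 `CCCCCCOP(=O)(O)OCCSC(=S)N1CCCCC1`, which differs from compound 2 in one place: piperidin-1-yl in place of pyrrolidin-1-yl on a thiocarbonyl carbon. Within the data shown here, only one measured step bears on this change, since it also exchanges the ring on the thiocarbonyl carbon: a 3.1-fold higher number from compound 1 to compound 2 (0.50 log units; beyond the scatter). Piperidin-1-yl lies between azepan-1-yl and pyrrolidin-1-yl in ring size, so part of that step is expected to be reversed, though a single step cannot show whether the trend runs evenly. The expected step is a 1.8-fold lower number from compound 2 to compound 3 (0.26 log units; within the scatter), towards a lower number and smaller than the measured one. For compound 3, the estimate in this assay is 30000 nM, with an expected range of 14000 nM to 62000 nM.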

Compound 3, half-maximal inhibitory concentration: 85000 nM
Compound 3: the middle estimate sits 2.8-fold (0.45 log units) below what was measured; measured number above the stated range.
By their numbers in this assay, from the lowest: compound 1; then compounds 2 and 3 (each within the scatter of the next).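

In this assay the move from pyrrolidin-1-yl to piperidin-1-yl on a thiocarbonyl carbon is not a readable change (a 1.6-fold higher number from compound 2 to compound 3 (0.20 log units; within the scatter)), so these two rings cannot be told apart at this position. The step away from azepan-1-yl is the clearer one (a 4.9-fold higher number from compound 1 to compound 3 (0.69 log units; beyond the scatter)), and together with the earlier step it leaves compound 1 as the strongest inhibitor of the three, the only one that separates from the others. Nothing at hand explains why only azepan-1-yl stands apart.

The compounds shown leave open whether an open-chain amine such as diethylamino, or a morpholine ring, on the thiocarbonyl carbon would match azepan-1-yl or fall with the two other rings. They also leave open whether a longer alkyl chain in the shared core would alter this picture.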